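Chloro for Acetamido on a Naphthalene Sulfonamide

The compounds below may be only part of what the source reports. "The series", "measured", "known", "first", "only" and "open" are said of these compounds alone.

compound 1 `COc1ccc(Br)cc1S(=O)(=O)N1CCC(N2CCC(C)CC2)CC1`: > 5000 nM
compound 2 `CC(=O)Nc1ccc(S(=O)(=O)N2CCC(N3CCC(C)CC3)CC2)c2ccccc12`: > 10000 nM

In an ADME assay on HCT-116 cells (Homo sapiens) for cytotoxicity, read by CellTiter-Glo, with a stated time of 72 h (a higher number here means a weaker inhibitor, a lower number a stronger inhibitor), compound 1 gives > 5000 nM, which is a limit of the assay rather than a number. Compound 2, `CC(=O)Nc1ccc(S(=O)(=O)N2CCC(N3CCC(C)CC3)CC2)c2ccccc12`, is likewise reported only as a limit, > 10000 nM, so its true value is not known beyond that bound. Compound 3, `CC1CCN(C2CCN(S(=O)(=O)c3ccc(Cl)c4ccccc34)CC2)CC1`, differs from compound 2 by chloro in place of acetamido on an aromatic carbon. Among the measured compounds shown here, no measured step between the two limited compounds gives a scale for such a change, so any expectation rests on the limit alone. The step of an at least 1.2-fold lower number from compound 2 to compound 3 (0.09 log units; that floor lies within the scatter) is expected to be small. Compound 3 is estimated at 8000 nM, with a likely range from 2000 nM to 30000 nM.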

Compound 3, half-maximal inhibitory concentration: > 10000 nM
Compound 3 gave a limit, no number; the forecaster's own chance of this, stated with the estimate: 60%; middle value at least 1.2-fold (0.09 log units) from the limit.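

In this assay compound 3 gives > 10000 nM, a limit and not a number. Compound 2 is also a limit, so no step can be read between compound 2 and compound 3. As far as these compounds go, whether chloro and acetamido differ at all in this assay stays open.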